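Morpholine to Thiomorpholine on a Pyridine Thiosemicarbazone

The compounds below may be only part of what the source reports. "The series", "measured", "known", "first", "only" and "open" are said of these compounds alone.

Two close relatives share a core and differ only in the ring attached to the thiocarbonyl carbon. Compound 1 `N/C(=N\NC(=S)N1CCCCCC1)c1ccccn1` carries a seven-membered ring there; in a functional assay on MCF7 cells (Homo sapiens) for cytotoxicity, read by MTT assay, with a stated time of 72 h, tested at 100 uM (a lower number here means less inhibition of growth, a higher number more inhibition of growth at the concentration tested), compound 1 gives 84%. Compound 2 `N/C(=N\NC(=S)N1CCOCC1)c1ccccn1` carries a morpholine ring; in this assay compound 2 gives 81.6%. Compound 2 holds the lower of the two measured numbers, yet the gap to compound 1 lies within the usual scatter, so the two cannot be told apart on these data.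

Compound 3 `N/C(=N\NC(=S)N1CCSCC1)c1ccccn1` has not been measured. It differs from compound 2 by thiomorpholin-4-yl in place of morpholin-4-yl on a thiocarbonyl carbon. Among the measured compounds shown here, no measured pair shows what this exchange does, and the two values in hand change little across a ring swap at the same position.

The step of a number 0.4 percentage points higher from compound 2 to compound 3 (within the scatter) is therefore expected to stay within the scatter, with no direction favoured. Compound 3 is estimated at 82%, with a range from 68% to 92%.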

Compound 3, percent growth inhibition at one concentration: 72.4%
Beside the measured number, compound 3's estimate is 9.6 percentage points above it, within the range that was stated.
By their numbers in this assay, from the lowest: compounds 3, 2 and 1 (each within the scatter of the next, the first and the last beyond it).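

The exchange of morpholin-4-yl for thiomorpholin-4-yl on a thiocarbonyl carbon now has a measured step, a number 9.2 percentage points lower from compound 2 to compound 3 (within the scatter) in this assay, so this single change cannot be told apart from the scatter of repeated measurements. Among the compounds shown here, the position is still not wholly indifferent to the ring it carries: compound 1 at 84% and compound 3 at 72.4% form the only pair here whose gap lies beyond the scatter, while compound 2 lies within the scatter of both. No evidence is available that bears on this result.

The compounds shown leave open how a piperazine ring, with a nitrogen as its second ring atom, would read at this position. On these data alone, an open-chain dimethylamino group in place of the ring is equally open.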